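The compounds below may be only part of what the source reports. "The series", "measured", "known", "first", "only" and "open" are said of these compounds alone.

Working notes on the series in an in vivo ADME assay on the whole organism (plasma) for pharmacokinetics, with Canis familiaris (Canis lupus familiaris) as the target, at a dose of 0.5 mg/kg by the intravenous route; a lower number here means slower removal, a higher number faster removal of the compound.

Three compounds have numbers. Compound 1 `COc1cc2nc(N3CCCN(C(=O)N4CCOCC4)CC3)nc(N)c2c(-c2ccccn2)c1OC` gives 20 mL/min/kg in this assay. Compound 2 `COc1cc2nc(N3CCCN(C(=O)N4CCOCC4)CC3)cc(N)c2c(-c2ccccc2)c1OC` gives 8.8 mL/min/kg in this assay. Compound 3 `COc1cc2nc(N3CCc4ncccc4C3)nc(N)c2c(-c2ncccn2)c1OC` gives 40 mL/min/kg in this assay. Compound 2 therefore holds the lowest number of the three; its gaps to compound 1 and to compound 3 both lie beyond the usual scatter of this assay, with compound 3 furthest away. No pair among these three differs in one place only, so no single step can be read from them.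

Compound 4 `COc1cc2nc(N3CCCN(C(=O)N4CCOCC4)CC3)cc(N)c2c(-c2ccc(F)cc2)c1OC` has not yet been measured in this assay. It differs from compound 2 by fluoro in place of hydrogen on an aromatic carbon. Going by the values given here, no measured pair shows this change, so the size of the step rests on the change alone: one fluorine added with no ring, no donor and no acceptor. The expected step of a 1.0-fold lower number from compound 2 to compound 4 (0.02 log units; within the scatter) is small, in no clear direction, and not beyond the scatter. For compound 4 the expected number in this assay is 8.5 mL/min/kg, with a range from 4.5 mL/min/kg to 16 mL/min/kg.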

Compound 4, clearance in the Canis familiaris assay: 15 mL/min/kg
For compound 4 the middle estimate is 1.8-fold (0.25 log units) below the measured one, and the stated range covers the measured number.
By their numbers in the Canis familiaris assay, from the lowest: compounds 2, 4, 1 and 3 (each within the scatter of the next, the first and the last beyond it).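

In the Canis familiaris assay compound 2 gives 8.8 mL/min/kg, compound 4 gives 15 mL/min/kg, and the change from phenyl to 4-fluorophenyl, fluoro in place of hydrogen on an aromatic carbon para to a large group, gives a 1.7-fold higher number from compound 2 to compound 4 (0.23 log units; within the scatter) and so, in this single pair, cannot be told apart from no change in clearance. In a physicochemical assay for acid dissociation, compound 2 gives 8.5, compound 4 gives 8.5, and the same change gives no change at the digits printed from compound 2 to compound 4 (within the scatter) and so leaves the acid dissociation constant as it stands in this pair. No supporting data bear on the clearance numbers of this pair.

Going by these compounds, whether another group at this place, such as chloro, methoxy or an amine, would give a step beyond the scatter remains open. On these data alone, it is also open whether fluoro on another carbon of the same ring would give a step of a different size.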